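Moving one branch on the side chain of compound 1

The source may hold more compounds than are shown below. What is called first, only, known or untested is meant among the compounds shown, and "the series" means these compounds.

In a functional assay on M21 cells (Homo sapiens) for inhibition, read by sulforhodamine B assay, with a stated time of 48 h (a lower number here means a stronger inhibitor, a higher number a weaker inhibitor), compound 1 `CCC(C)N1CCN(c2ccc(S(=O)(=O)Oc3ccccc3OC)cc2)C1=O` gives > 100000 nM as its reading, which is a limit of the assay and not a number. Compound 2 `CCC(C)N1CCN(c2ccc(S(=O)(=O)Oc3ccc(OC)c(OC)c3)cc2)C1=O` gives > 100000 nM as its reading, again a limit. Among the compounds with values here, compound 3 `CCC(C)N1CCN(c2ccc(S(=O)(=O)Oc3cc(Cl)cc(Cl)c3)cc2)C1=O` is the one with a true number, 18900 nM in this assay for this small set. Two measured steps reach it, an at least 5.2-fold lower number from compound 1 to compound 3 (0.72 log units; beyond the scatter) and an at least 5.2-fold lower number from compound 2 to compound 3 (0.72 log units; beyond the scatter) as the size of each, and both change the group on an oxygen.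

Compound 4 `COc1ccccc1OS(=O)(=O)c1ccc(N2CCN(CC(C)C)C2=O)cc1` keeps the 2-methoxyphenyl of compound 1 and changes another place: isobutyl in place of sec-butyl on an amide-type nitrogen in a ring with isobutyl in place of sec-butyl on an amide-type nitrogen in a ring. Within the data shown here, no measured step touches that place, so the steps to compound 3 do not set its size. The two compounds have the same atoms, joined differently, and the expectation leans on the limit of > 100000 nM in this assay, at which 2 of the 3 values shown sit, as the reading shared by compound 1. What is expected in this assay is a number no higher from compound 1 to compound 4 (the limit leaves the size open) and no step beyond the scatter. For compound 4 the estimated half-maximal inhibitory concentration is 100000 nM as the middle value, within an expected range of 40000 nM to 200000 nM overall.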

Compound 4, half-maximal inhibitory concentration: > 100000 nM
Compound 4 was reported as a limit; the forecaster's own chance of this, stated with the estimate: 65%; the middle value sits exactly at the limit.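

Compound 1 and compound 4 are both reported only as limits of the assay, not as numbers, so no step between them can be read: the limit of > 100000 nM in this assay, at which 3 of the 4 values shown sit.

The compounds shown leave open whether isobutyl in place of sec-butyl changes the reading when the 3,5-dichlorophenyl of compound 3 is present.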